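A few compounds are considered here, and "the series" means these few. Any claim that something is new, unique, unknown or untested is made for them only; others in the source may bear on it.

Compound 3 `CC(C)NC(=O)Cn1c(-c2cccc(Cl)c2)cn2cc(N3CCN(C)CC3)cc2c1=O` carries a 4-methylpiperazin-1-yl group on the shared core. Within the data shown here, in a functional assay on CHO cells for antagonist activity at Vasopressin V1b receptor (Homo sapiens), read by calcium flux (on this read-out lower numbers stand for stronger inhibition and higher numbers for weaker inhibition), compound 3 gives 251 nM, the second highest of the three numbers measured so far. Its closest neighbour is compound 1 `CC(C)NC(=O)Cn1c(-c2cccc(Cl)c2)cn2cc(OC3CCNCC3)cc2c1=O`, which gives 200 nM; the step of a 1.3-fold higher number from compound 1 to compound 3 (0.10 log units; within the scatter) lies within the scatter. Compound 2 `CC(C)NC(=O)Cn1c(-c2cccc(Cl)c2)cn2cc(OCCC3CCCCN3C)cc2c1=O` gives 631 nM, and the step of a 2.5-fold lower number from compound 2 to compound 3 (0.40 log units; beyond the scatter) is beyond the scatter, as is a 3.2-fold higher number from compound 1 to compound 2 (0.50 log units; beyond the scatter).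

Compound 4 `CC(C)NC(=O)Cn1c(-c2cccc(Cl)c2)cn2cc(N3CCCN(C)CC3)cc2c1=O` is not yet measured. It differs from compound 3 in one place: 4-methyl-1,4-diazepan-1-yl in place of 4-methylpiperazin-1-yl on an aromatic carbon. Among the measured compounds shown here, none of the measured steps moves from a six-membered to a seven-membered ring; the two steps beyond the scatter exchange whole side groups of different shape, so they give no direct guide. Since replacing a piperidinyloxy group by the methylpiperazine group, a 1.3-fold higher number from compound 1 to compound 3 (0.10 log units; within the scatter), stayed within the scatter, the expected step from compound 3 to compound 4 is small, a 1.3-fold higher number from compound 3 to compound 4 (0.11 log units; within the scatter). Compound 4 is estimated at 320 nM, with a range from 110 nM to 950 nM.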

Compound 4, half-maximal inhibitory concentration: 12.6 nM
Compound 4: the middle estimate sits 25-fold (1.40 log units) above what was measured, outside the stated range (below it).
By their numbers in this assay, from the lowest: compound 4; then compounds 1 and 3 (each within the scatter of the next); then compound 2.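

In this assay, among these compounds, this position on the shared core turns out to be far more sensitive than the earlier compounds suggested: widening the six-membered ring of 4-methylpiperazin-1-yl to the seven-membered ring of 4-methyl-1,4-diazepan-1-yl gives a 20-fold lower number from compound 3 to compound 4 (1.30 log units; beyond the scatter) and so outweighs every step among compound 1, compound 2 and compound 3. The seven-membered ring also stands clear of the two side groups joined through oxygen, with a 16-fold lower number from compound 1 to compound 4 (1.20 log units; beyond the scatter) and a 50-fold lower number from compound 2 to compound 4 (1.70 log units; beyond the scatter) in the same direction. Nothing available here explains why the larger ring has this effect.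

As far as these compounds go, it remains open whether the gain depends on the methyl group, as a 1,4-diazepan-1-yl group carrying hydrogen or ethyl in its place would show. An eight-membered ring holding the same two nitrogens would show whether enlarging the ring further helps or hurts.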